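Methoxy in place of hydrogen on the aryl ring

The compounds below may be only part of what the source reports. "The series", "measured", "known", "first", "only" and "open" are said of these compounds alone.

Measured compounds:
- Compound 1, `Cc1cccc(-n2cnc3cc(C(=O)N4CCC(Br)CC4)ccc32)c1`: in an assay on isolated protein for inhibition of 15-hydroxyprostaglandin dehydrogenase [NAD(+)] (Homo sapiens), read by fluorescence, with a stated time of 15 min (on this read-out higher numbers stand for weaker inhibition and lower numbers for stronger inhibition), compound 1 gives 76 nM.
- Compound 2, `O=C(c1ccc2c(c1)ncn2-c1ccccc1)N1CCCCC1`: in this assay compound 2 gives 22 nM.

Compound 2 holds the lowest of the two numbers in this assay. Compound 1 sits higher, and the gap between the two lies beyond the scatter; since the two compounds differ at both the aryl substituent and the saturated ring on the amide, the pair shows only its two values and no single step can be read from it.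

Compound 3, `COc1cccc(-n2cnc3cc(C(=O)N4CCCCC4)ccc32)c1`, is compound 2 with methoxy in place of hydrogen on an aromatic carbon. Among the compounds with values here, no measured pair isolates this change. On the shared core the aryl ring already carries a substituent at this position in compound 1 without the number leaving the same order of magnitude, so a modest step is expected, in either direction or none beyond the scatter. The step from compound 2 to compound 3 is expected at a 1.3-fold higher number from compound 2 to compound 3 (0.10 log units; within the scatter). Compound 3 is accordingly estimated at 28 nM in this assay, with a range from 10 nM to 80 nM.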

Compound 3, half-maximal inhibitory concentration: 19 nM
Compound 3: middle estimate off by 1.5-fold (0.17 log units), on the high side; measured number inside the range.
By their numbers in this assay, from the lowest: compounds 3 and 2 (each within the scatter of the next); then compound 1.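

In this assay the step reads a 1.2-fold lower number from compound 2 to compound 3 (0.06 log units; within the scatter) for methoxy in place of hydrogen on an aromatic carbon, meta to a large group. Within the data shown here, this is the first pair that differs in one place, so the phenyl to 3-methoxyphenyl change can be read on its own, with the saturated ring on the amide held constant, whereas compound 1 differs from compound 2 at both the aryl substituent and that ring. The position therefore accepts methoxy with the values of compound 2 and compound 3 within the scatter of each other, although no measurement shown bears on what lies behind this result.

The separate contributions of the methyl on the aryl ring and the bromine on the saturated ring in compound 1 cannot be read from the compounds shown. Going by these compounds, it also remains open whether the same aromatic carbon tolerates groups of another kind, such as an amine, a carboxylic acid or a longer chain like butoxy, and whether methoxy behaves alike at the other aromatic carbons of that ring.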